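Replacing 2,4-dichlorophenyl with 2-bromophenyl

The compounds below may be only part of what the source reports. "The series", "measured", "known", "first", "only" and "open" are said of these compounds alone.

Of the compounds shown here, three built on a shared core have been tested in a functional assay on Lewis lung carcinoma cells for cytotoxicity against Lewis lung carcinoma cell line (Mus musculus), read by MTT assay, with a stated time of 72 h; a higher number here means a weaker inhibitor, a lower number a stronger inhibitor. Compound 1 (`COc1ccc(/C=C2\COC/C(=C\c3ccccc3F)C2=O)cc1O`) gives 9600 nM and compound 2 (`COc1cc(/C=C2\COC/C(=C\c3ccccc3F)C2=O)ccc1O`) gives 13100 nM in this test, two values within the usual scatter of each other. Compound 3 (`O=C1/C(=C/c2ccccc2F)COC/C1=C\c1ccc(Cl)cc1Cl`) stands at 29400 nM as the highest of the three numbers, beyond the scatter from both of the others, which makes it the weakest of the set.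

Compound 4 (`O=C1/C(=C/c2ccccc2F)COC/C1=C\c1ccccc1Br`) has not yet been measured. It carries 2-bromophenyl in place of 2,4-dichlorophenyl on a double-bonded chain carbon bound to a double-bonded ring carbon. For the measured compounds named here, no measured pair differs in one place only, so no direct precedent exists for this step. Compound 3 at 29400 nM sits at the top of the set, so in this assay a small move toward a lower number is expected, with nothing clearly beyond the scatter. The estimated step runs a 1.8-fold lower number from compound 3 to compound 4 (0.26 log units; within the scatter) in that direction. For compound 4 the expected value is 16000 nM within an estimated range of 7000 nM to 35000 nM once it is measured.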

Compound 4, half-maximal inhibitory concentration: 13300 nM
Compound 4: middle estimate off by 1.2-fold (0.08 log units), on the high side, and the stated range covers the measured number.
By their numbers in this assay, from the lowest: compounds 1, 2 and 4 (each within the scatter of the next); then compound 3.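

In this assay, for the compounds shown here, replacing 2,4-dichlorophenyl with 2-bromophenyl on a double-bonded chain carbon bound to a double-bonded ring carbon gives a 2.2-fold lower number from compound 3 to compound 4 (0.34 log units; beyond the scatter), the first single-place step at this position. The step is modest but beyond the scatter, showing that this position can register a change of aryl group and that compound 3 is not simply a fixed feature of the series; compound 4 now falls with compounds 1 and 2, each within the scatter of the next. Nothing measured here explains the step.

Because the change removes both chlorines and adds a bromine, the compounds shown do not separate these contributions, and 2-chlorophenyl at this position would bear on that question. From the compounds shown here alone, how a phenyl ring carrying an amine or a carboxylic acid would behave here also remains open.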